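Pyridine amide series: difluorophenyl for dimethylphenyl swap

This account rests on a few compounds, and the source may have more. Where it says the series, first, only, none or still open, it means among the compounds named here.

Measured compounds in a functional assay on A549 cells (Homo sapiens) for cytotoxicity, read by MTT assay, with a stated time of 72 h; a higher number here means a weaker inhibitor, a lower number a stronger inhibitor:
compound 1 `O=C(Nc1ccc(Oc2ccnc3[nH]ccc23)cc1)c1ccc(-c2ccc(F)cc2F)cn1`, > 10000 nM (a limit of the assay, not a number)
compound 2 `COc1ccc(-c2ccc(C(=O)Nc3ccc(Oc4ccnc5[nH]ccc45)c(F)c3)nc2)cc1`, 2240 nM
compound 3 `Cc1ccc(-c2ccnc(C(=O)Nc3ccc(Oc4ccnc5[nH]ccc45)c(F)c3)c2)c(C)c1`, 4350 nM

Compound 3 gives the higher of the two actual numbers in this assay, but its nearest neighbour compound 2 sits within the scatter of it, so no order between the two can be read. Compound 1 reaches only the limit; that limit is the limit of > 10000 nM in this assay, at which 1 of the 3 values shown sits.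

Compound 4 `O=C(Nc1ccc(Oc2ccnc3[nH]ccc23)c(F)c1)c1cc(-c2ccc(F)cc2F)ccn1` has not yet been measured. It differs from compound 3 in one place: 2,4-difluorophenyl in place of 2,4-dimethylphenyl on an aromatic carbon. For the measured compounds named here, no measured pair in the set shows this change on its own. Compound 1 carries the same 2,4-difluorophenyl group on a different part of the core and gives only a limit, which leaves the expected size of the step open.

The step from compound 3 to compound 4 is expected to be small, a modest weakening at most, estimated as a 1.5-fold higher number from compound 3 to compound 4 (0.17 log units; within the scatter). For compound 4 the expected value in this assay is 6500 nM, with a range from 2000 nM to 20000 nM; a limit instead of a number is a real possibility.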

Compound 4, half-maximal inhibitory concentration: > 10000 nM
Compound 4 ended at the assay's limit (the forecaster's own chance of this, stated with the estimate: 30%); middle value at least 1.5-fold (0.18 log units) away from the limit.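

For the compounds shown here, on the aromatic carbon opposite the ring nitrogen, 2,4-difluorophenyl in place of 2,4-dimethylphenyl gives, in this assay, an at least 2.2-fold higher number from compound 3 to compound 4 (0.36 log units; beyond the scatter), the first single-place step and one that lies beyond the scatter. Compound 4 gives > 10000 nM, a limit of the assay and not a number, so the step has a lower bound but no measured size. Compound 1 and compound 4, the two compounds carrying 2,4-difluorophenyl, are also the two compounds that reach the limit, while compound 2 and compound 3 give actual numbers: the limit of > 10000 nM in this assay, at which 2 of the 4 values shown sit.

The two substituent sites on the phenyl ring change together in this swap, so the contribution of each site cannot be separated, and a phenyl with a single fluorine or a single methyl would be needed to divide the step. Going by these compounds, whether this position tolerates a different kind of group, such as an amine, a carboxylic acid or a longer alkyl chain, and whether any of these would return a value within the range of this assay, remains open.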